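Carbamate variation on a selenocyanate aryl core

The compounds below may be only part of what the source reports. "The series", "measured", "known", "first", "only" and "open" are said of these compounds alone.

Measured compounds:
compound 1 `N#C[Se]c1ccc(NC(=O)Oc2ccc(F)cc2)cc1` — 71100 nM
compound 2 `N#C[Se]c1ccc(NC(=O)Oc2ccc(Cl)cc2)cc1` — 71800 nM
compound 3 `CCOC(=O)Nc1ccc([Se]C#N)cc1` — 68800 nM

In a functional assay on CCRF-CEM cells (Homo sapiens) for cytotoxicity, read by MTT assay, with a stated time of 72 h (on this read-out lower numbers stand for higher toxicity in this test and higher numbers for lower toxicity in this test), compound 1 gives 71100 nM and compound 2 gives 71800 nM; the step of a 1.0-fold higher number from compound 1 to compound 2 (0.00 log units; within the scatter) shows that swapping the halogen on the aryl carbamate ring leaves the read-out unchanged. Compound 3, the ethyl carbamate, gives 68800 nM in this assay, the lowest of the three numbers, though its gaps to compound 1 and compound 2 both fall within the scatter, so the three compounds cannot be ordered on these data.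

Compound 4 `N#C[Se]c1ccc(NC(=O)Oc2ccccc2)cc1` has not been measured. Relative to compound 3 the change is phenyl in place of ethyl on an oxygen next to a carbonyl group. Going by the values given here, no measured step covers exactly this change. Among the compounds with values here, the only measured step, a 1.0-fold higher number from compound 1 to compound 2 (0.00 log units; within the scatter), concerns a different position and was flat; it is relevant only in showing that the aryl carbamate part tolerates substitution without effect. Compound 1 and compound 2 differ from compound 4 only by a halogen, and their values sit beside that of compound 3.

The expected step of a 1.0-fold higher number from compound 3 to compound 4 (0.01 log units; within the scatter) is therefore none beyond the scatter. Compound 4 is estimated at 70000 nM in this assay, with a range from 40000 nM to 120000 nM.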

Compound 4, concentration lethal to 50% of the cells: 73200 nM
Compound 4: middle estimate off by 1.0-fold (0.02 log units), on the low side; measured number inside the range.
By their numbers in this assay, from the lowest: compounds 3, 1, 2 and 4 (each within the scatter of the next).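

In this assay, phenyl in place of ethyl on an oxygen next to a carbonyl group gives a 1.1-fold higher number from compound 3 to compound 4 (0.03 log units; within the scatter), so this exchange, the first measured here at this oxygen between an alkyl and an aryl group without a halogen, leaves the read-out unresolved from the ethyl carbamate. The unsubstituted phenyl also extends the earlier flat halogen swap: hydrogen in place of chloro on an aromatic carbon gives a 1.0-fold higher number from compound 2 to compound 4 (0.01 log units; within the scatter) and removing the fluoro gives a 1.0-fold higher number from compound 1 to compound 4 (0.01 log units; within the scatter), which means that removing the halogen, and not only exchanging one halogen for the other, shows no effect beyond the scatter among these compounds. Nothing available bears on what lies behind these flat steps.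

The compounds shown leave open whether a group of another kind on this oxygen, such as a longer chain or a chain carrying an amine or a carboxylic acid, would move the number beyond the scatter. Also open, on these data alone, is whether a ring substituent other than a halogen, such as methoxy or nitro, would do so on the phenyl ring.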